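Swapping the benzyl group on a weak inhibitor

This account rests on a few compounds, and the source may have more. Where it says the series, first, only, none or still open, it means among the compounds named here.

Compound 1 (`CC(C)(C)c1cc(CCC(=O)NCCC2CCN(Cc3ccccc3)CC2)cc(C(C)(C)C)c1O`) gives 54500 nM in a functional assay, read by spectrophotometry, with a stated time of 30 min (on this read-out lower numbers stand for stronger inhibition and higher numbers for weaker inhibition), and compound 2 (`Cc1ccccc1CN1CCC(CCNC(=O)/C=C/c2cc(C(C)(C)C)c(O)c(C(C)(C)C)c2)CC1`) gives 65300 nM in this assay too. These two numbers lie within the usual scatter of repeat measurements, so compound 2 stands level with compound 1 and neither can be ranked above the other.

Compound 3 (`CC(C)(C)c1cc(/C=C/C(=O)NCCC2CCN(Cc3ccc(F)cc3)CC2)cc(C(C)(C)C)c1O`) has not been measured yet. Compared with compound 2, it carries 4-fluorophenyl in place of 2-methylphenyl on a saturated chain carbon bound to an amine nitrogen in a ring and is otherwise the same. Read one bond further out, this is 2-methylbenzyl to 4-fluorobenzyl.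

Among the compounds with values here, no two measured compounds differ in one place only, so the data do not show what such a swap does. For that reason, no step beyond the scatter is expected in this assay and neither direction is favoured. The expected step of a 1.2-fold lower number from compound 2 to compound 3 (0.07 log units; within the scatter) is therefore small. For compound 3 the estimate is 55000 nM within an expected range of 20000 nM to 120000 nM in this assay as well.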

Compound 3, half-maximal inhibitory concentration: 57500 nM
Compound 3: middle estimate off by 1.0-fold (0.02 log units), on the low side; the range from low to high includes it.
By their numbers in this assay, from the lowest: compounds 1, 3 and 2 (each within the scatter of the next).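

The swap of 2-methylbenzyl for 4-fluorobenzyl gives a 1.1-fold lower number from compound 2 to compound 3 (0.06 log units; within the scatter) in this assay, and this is the first pair shown that differs in one place only. At this position, on a saturated chain carbon bound to an amine nitrogen in a ring, 2-methylphenyl and 4-fluorophenyl therefore cannot be told apart, and compound 2 and compound 3 stand level as weak inhibitors. No other measurement bears on this result, so nothing here explains it.

On these data alone, both groups are six-membered aromatic rings of carbon only, so it remains open whether a different kind of group at this place, such as a benzyl ring carrying a carboxylic acid or an amine, or a longer chain in place of the single carbon leading to the ring nitrogen, would give a step beyond the scatter. As far as these compounds go, compound 1 differs from each of the other two compounds in more than one place, so its steps to them cannot be read, and the separate effect of the link to the shared phenol-bearing end also stays open.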